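Working notes: side-chain exchange on the shared core

This account rests on a few compounds, and the source may have more. Where it says the series, first, only, none or still open, it means among the compounds named here.

Values in an ADME assay on WI-38 cells (Homo sapiens) for cytotoxicity, read by MTT assay, with a stated time of 48 h; on this read-out higher numbers stand for weaker inhibition and lower numbers for stronger inhibition:
- compound 1 `CCOC(=O)C1=C(N/C=N/c2cccnc2Cl)Nc2[nH]nc(C)c2C1c1ccc(N(C)C)cc1`: 74500 nM
- compound 2 `CCOC(=O)C1=C(NN=C(C(C)=O)C(C)=O)Nc2[nH]nc(C)c2C1c1ccc(N(C)C)cc1`: 61400 nM

The values of compound 2 and compound 1 lie within the scatter of each other. Compound 3 `CCOC(=O)C1=C(NN=C(C#N)C#N)Nc2[nH]nc(C)c2C1c1ccc(N(C)C)cc1` differs from compound 2 by a group of 6 heavy atoms (3 carbon, 3 nitrogen; no ring) in place of a group of 8 heavy atoms (5 carbon, 1 nitrogen, 2 oxygen; no ring), on an amine nitrogen. Within the data shown here, the only measured step bearing on this is a 1.2-fold lower number from compound 1 to compound 2 (0.08 log units; within the scatter), also an exchange on an amine nitrogen. In this assay, no shift beyond the scatter is therefore expected, and the expected step is a 1.1-fold lower number from compound 2 to compound 3 (0.05 log units; within the scatter). For compound 3 the estimated value is 55000 nM, with an expected range of 22000 nM to 130000 nM.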

Compound 3, half-maximal inhibitory concentration: 42700 nM
Compound 3: the middle estimate sits 1.3-fold (0.11 log units) above what was measured; the range from low to high includes it.
By their numbers in this assay, from the lowest: compounds 3, 2 and 1 (each within the scatter of the next).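

In this assay, the exchange on the amine nitrogen now extends to a side chain carrying nitrile groups, and neither a 1.4-fold lower number from compound 2 to compound 3 (0.16 log units; within the scatter) nor a 1.7-fold lower number from compound 1 to compound 3 (0.24 log units; within the scatter) leaves the scatter. The three side chains, one with a ring and two without, therefore give values that cannot be told apart at this position. No measurement at hand accounts for this flat picture.

From the compounds shown here alone, whether a side chain bearing an amine or a carboxylic acid would move the value beyond the scatter remains open. The compounds shown also leave open how changes elsewhere on the shared core would act.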